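This account rests on a few compounds, and the source may have more. Where it says the series, first, only, none or still open, it means among the compounds named here.

Within the data shown here, in an ADME assay (liver) for metabolic stability, with Liver microsome (Rattus norvegicus) as the target, using microsomes and NADPH, with a stated time of 30 min, tested at 1 uM (a lower number here means slower removal, a higher number faster removal of the compound), compound 2 (`Nc1ccc(S(=O)(=O)N2CCN(c3ncc(C(O)(C(F)(F)F)C(F)(F)F)cc3-c3cccc4[nH]ncc34)CC2)cn1`) gives 93 mL.min-1.g-1, the lower of the two numbers measured so far. Among the measured compounds shown here, the only other measured compound, compound 1 (`Cc1csc(-c2cc(C(O)(C(F)(F)F)C(F)(F)F)cnc2N2CCN(S(=O)(=O)c3ccc(N)nc3)CC2)c1`), gives 399 mL.min-1.g-1. These two differ in one place: 1H-indazol-4-yl stands in place of 4-methylthiophen-2-yl, and the data show a 4.3-fold lower number from compound 1 to compound 2 (0.63 log units; beyond the scatter), a modest step beyond the scatter. Compound 3 (`Nc1ccc(S(=O)(=O)N2CCN(c3ncc(C(O)(C(F)(F)F)C(F)(F)F)cc3-c3cc4ccccc4[nH]3)CC2)cn1`) changes that same place again, on an aromatic carbon of a six-membered aromatic ring with 1 nitrogen, ortho to a large group: 1H-indol-2-yl in place of 1H-indazol-4-yl on an aromatic carbon. For the measured compounds named here, no measured step covers this exact exchange, so the single step at this place is the only guide, and it shows that this position can move the number in this assay. The group entering is neither of the two already measured, so compound 3 is expected to land somewhere within the span set by compound 2 at 93 mL.min-1.g-1 and compound 1 at 399 mL.min-1.g-1, probably in its middle. The estimated change is a 2.0-fold higher number from compound 2 to compound 3 (0.31 log units; beyond the scatter), an expected rise of modest size. For compound 3 the expected value is 190 mL.min-1.g-1, with an estimated range from 85 mL.min-1.g-1 to 420 mL.min-1.g-1.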

Compound 3, intrinsic clearance in microsomes: 146 mL.min-1.g-1
The estimate for compound 3 lay 1.3-fold (0.11 log units) above the measured number; the measured number falls inside the stated range.
By their numbers in this assay, from the lowest: compounds 2 and 3 (each within the scatter of the next); then compound 1.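

In this assay, 1H-indol-2-yl in place of 1H-indazol-4-yl gives a 1.6-fold higher number from compound 2 to compound 3 (0.20 log units; within the scatter), so compounds 2 and 3 cannot be told apart here, even though the entering group has a five-membered aromatic ring with 1 hetero atom where the leaving group has one with 2 hetero atoms. Measured against 4-methylthiophen-2-yl, the same group gives a 2.7-fold lower number from compound 1 to compound 3 (0.44 log units; beyond the scatter), which shows that the lower number at this position is not confined to 1H-indazol-4-yl, and among the three compounds only compound 1 stands apart. Nothing available explains this difference between the groups at this position.

The compounds shown leave open whether a single ring, such as unsubstituted phenyl or a pyridine, would stay with compounds 2 and 3 or move towards compound 1, and whether the methyl on the thiophene of compound 1 matters at all. They also leave open whether an amine or a carboxylic acid carried on the 1H-indol-2-yl group would shift the number in this assay beyond the scatter.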